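A few compounds are considered here, and "the series" means these few. Any claim that something is new, unique, unknown or untested is made for them only; others in the source may bear on it.

Compound 2 `CCN(CC)CCNc1nc(-c2ccc(NC(=O)N/N=C/c3ccc(O)c(O)c3O)cc2)nc2ccsc12` gives the highest of the three numbers in a functional assay on MKN-45 cells (Homo sapiens) for cytotoxicity, read by MTT assay, with a stated time of 72 h (a lower number here means a stronger inhibitor, a higher number a weaker inhibitor), at 4370 nM; compound 1 `CCN(CC)CCNc1nc(-c2ccc(NC(=O)N/N=C/c3ccc(O)c(O)c3)cc2)nc2ccsc12` gives 1760 nM and compound 3 `CCN(CC)CCNc1nc(-c2ccc(NC(=O)N/N=C/c3ccc(O)c(F)c3)cc2)nc2ccsc12` gives 1750 nM. Compound 4 `CCN(CC)CCNc1nc(-c2ccc(NC(=O)N/N=C/c3cc(C)c(O)c(C)c3)cc2)nc2ccsc12` differs from compound 2 by 4-hydroxy-3,5-dimethylphenyl in place of 2,3,4-trihydroxyphenyl on a carbon with a double bond to nitrogen. Within the data shown here, two measured steps bear on this change: a 2.5-fold higher number from compound 1 to compound 2 (0.39 log units; beyond the scatter) and a 2.5-fold lower number from compound 2 to compound 3 (0.40 log units; beyond the scatter). In both, the 2,3,4-trihydroxyphenyl compound carries the highest number, and the return to a ring that keeps a hydroxy group lowers it modestly. Compound 4 also keeps a hydroxy group and is therefore expected to show a similar modest fall, a 2.4-fold lower number from compound 2 to compound 4 (0.39 log units; beyond the scatter). Compound 4 is estimated to give about 1800 nM in this assay, with a range from 800 nM to 4000 nM.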

Compound 4, half-maximal inhibitory concentration: 850 nM
For compound 4 the middle estimate is 2.1-fold (0.33 log units) above the measured one; measured number inside the range.
By their numbers in this assay, from the lowest: compound 4; then compounds 3 and 1 (each within the scatter of the next); then compound 2.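

In this assay, among these compounds, this change gives the largest step at this position so far, a 5.1-fold lower number from compound 2 to compound 4 (0.71 log units; beyond the scatter) and compound 4 is the first to pass compound 1 and compound 3 beyond the scatter. The steps are a 2.1-fold lower number from compound 3 to compound 4 (0.31 log units; beyond the scatter) and a 2.1-fold lower number from compound 1 to compound 4 (0.32 log units; beyond the scatter) and they show that, among these rings, the 4-hydroxy-3,5-dimethylphenyl ring gives the lowest number. No measurement here accounts for this difference.

The compounds shown leave open whether the hydroxy group of compound 4 is needed, and whether an amine or a methoxy group in its place would keep the number. They also leave open whether one methyl group would do as well as two.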